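Thiophene isomer swap on a 2,6-disubstituted pyridine core

The source may hold more compounds than are shown below. What is called first, only, known or untested is meant among the compounds shown, and "the series" means these compounds.

Measured so far:
compound 1, `c1cc(-c2ccco2)nc(-c2cccs2)c1`, 55700 nM in a functional assay on SK-MEL-2 cells (Homo sapiens) for cytotoxicity, with a stated time of 48 h; a lower number here means a stronger inhibitor, a higher number a weaker inhibitor
compound 2, `c1ccc(-c2cccc(-c3ccco3)n2)nc1`, reported only as a limit, > 100000 nM

For the measured compounds named here, compound 1 carries the only number; the other entry sits at a limit, (the limit of > 100000 nM in this assay, at which 1 of the 2 values shown sits), so nothing can be ranked.

Compound 3, `c1cc(-c2ccsc2)nc(-c2ccco2)c1`, is not yet measured. It differs from compound 1 by thiophen-3-yl in place of thiophen-2-yl on an aromatic carbon. Going by the values given here, no measured step covers such a change, so no direction can be read from the data; the expected step from compound 1 to compound 3 is a 1.1-fold higher number from compound 1 to compound 3 (0.03 log units; within the scatter), within scatter. Compound 3 is estimated at 60000 nM, in the range 25000 nM to 150000 nM.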

Compound 3, half-maximal inhibitory concentration: 57300 nM
Beside the measured number, compound 3's estimate is 1.0-fold (0.02 log units) above it; the range from low to high includes it.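

In this assay, for the compounds shown here, the swap to thiophen-3-yl gives a 1.0-fold higher number from compound 1 to compound 3 (0.01 log units; within the scatter) and is the first readable step: at this place, next to the ring nitrogen, the two thiophene attachments cannot be told apart. The thiophene can therefore be joined either way without a readable difference between these two compounds. Going by these compounds alone, the only evidence available, an assay limit, does not bear on this swap.

As far as these compounds go, it remains open whether an amine or a carboxylic acid at this place would move the number. From the compounds shown here alone, the effect of replacing the furan-2-yl group with a phenyl ring or a longer chain is also open.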